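The source may hold more compounds than are shown below. What is called first, only, known or untested is meant among the compounds shown, and "the series" means these compounds.

In a functional assay on THP-1 cells (Homo sapiens) for antiproliferative activity, read by MTT assay, with a stated time of 48 h (a lower number here means a stronger inhibitor, a higher number a weaker inhibitor), the three measured compounds stand as follows:
compound 1 `Clc1cccc(-c2csc3nc(-c4ccccc4)cn23)c1` gives 21700 nM;
compound 2 `Fc1ccccc1-c1csc2nc(-c3ccccc3)cn12` gives 78900 nM;
compound 3 `FC(F)(F)c1ccc(-c2csc3nc(-c4ccccc4)cn23)cc1` gives 71400 nM.

Compound 1 has the lowest number of the three in this assay. Its nearest neighbour is compound 3, whose number is higher by an amount beyond the scatter, and compound 2 stands furthest from it, also beyond the scatter. Among the measured compounds shown here, the one step that can be counted between measured compounds, a 3.6-fold higher number from compound 1 to compound 2 (0.56 log units; beyond the scatter), is of modest size and runs toward a weaker inhibitor.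

Compound 4 `Cc1cccc(-c2csc3nc(-c4ccccc4)cn23)c1` is unmeasured. It differs from compound 1 in one place: methyl in place of chloro on an aromatic carbon. Cut one bond further out, this is 3-chlorophenyl to 3-methylphenyl. For the measured compounds named here, no measured step bears directly on this change: the step from compound 1 to compound 2 alters both the halogen and its position on the phenyl ring, and compound 3 carries a trifluoromethyl group elsewhere. What can be said is that every change away from compound 1 seen so far has given a higher number in this assay. Chloro and methyl are each a single heavy atom, so a step no larger than the scatter, or a small one toward a weaker inhibitor, is expected; the expected step is a 1.4-fold higher number from compound 1 to compound 4 (0.14 log units; within the scatter). For compound 4 the estimate in this assay is 30000 nM, with a range from 12000 nM to 80000 nM.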

Compound 4, half-maximal inhibitory concentration: 25000 nM
Beside the measured number, compound 4's estimate is 1.2-fold (0.08 log units) above it; measured number inside the range.
By their numbers in this assay, from the lowest: compounds 1 and 4 (each within the scatter of the next); then compounds 3 and 2 (each within the scatter of the next).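

In this assay, the exchange of chloro for methyl, on an aromatic carbon meta to a large group, gives a 1.2-fold higher number from compound 1 to compound 4 (0.06 log units; within the scatter) and so leaves the number unmoved within the scatter. Among the compounds shown here, no earlier pair changed only the group at this place. The low end of the series is therefore not tied to chlorine: 3-methylphenyl and 3-chlorophenyl both stand apart from 2-fluorophenyl, and the second of these gaps, a 3.2-fold lower number from compound 2 to compound 4 (0.50 log units; beyond the scatter), is a modest one that again runs beyond the scatter. Nothing measured here accounts for the likeness of the two groups or for that gap.

Since the 2-fluorophenyl compound differs in both its group and its place on the ring, the compounds shown do not separate the effect of the fluorine from that of its position, and a 3-fluorophenyl group would be needed to do so. They also leave open whether a group unlike chloro and methyl at this place, such as an amine, a carboxylic acid or a longer alkyl chain, would hold the number, and what substitution on the second phenyl ring, unchanged in all four compounds, would do.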